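The compounds below may be only part of what the source reports. "The series", "measured", "known", "first", "only" and "open" are said of these compounds alone.

Measured in a functional assay on HCT-15 cells (Homo sapiens) for antiproliferative activity; a higher number here means a weaker inhibitor, a lower number a stronger inhibitor:
Compound 1 `COc1ccc(S(=O)(=O)Oc2ccccc2NC(=O)c2ccc(F)cc2)cc1`: 89 nM
Compound 2 `COc1ccc(S(=O)(=O)Oc2ccccc2NC(=O)c2ccnc3ccccc23)cc1`: > 10000 nM (a limit)
Compound 3 `COc1ccc(S(=O)(=O)Oc2ccccc2NC(=O)c2ccc(N(C)C)cc2)cc1`: > 10000 nM (a limit)

Compound 3 has no number in this assay, only the limit > 10000 nM. It stands at the limit of > 10000 nM in this assay, at which 2 of the 3 values shown sit.

Compound 4 `COc1ccc(S(=O)(=O)Oc2ccccc2NC(=O)c2ccccc2)cc1` carries hydrogen in place of dimethylamino on an aromatic carbon, (hydrogen in place of dimethylamino on an aromatic carbon).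

The most relevant measured change lies at the same aromatic carbon, where dimethylamino in place of fluoro gives an at least 110-fold higher number from compound 1 to compound 3 (2.05 log units; beyond the scatter). With quinolin-4-yl in place of 4-fluorophenyl on a carbonyl carbon, the data show an at least 110-fold higher number from compound 1 to compound 2 (2.05 log units; beyond the scatter), so that change also reached the limit. The remaining comparison, a step that the two limits leave unreadable from compound 2 to compound 3, adds nothing.

Hydrogen itself is unmeasured at this place, so compound 1 at 89 nM is only the nearest guide. A large step to a lower number is therefore expected, though compound 4 may not fully match compound 1. The expected change is an at least 25-fold lower number from compound 3 to compound 4 (1.39 log units; beyond the scatter). For compound 4 the estimated value is 400 nM, with an expected range of 80 nM to 3000 nM.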

Compound 4, half-maximal inhibitory concentration: 310 nM
Beside the measured number, compound 4's estimate is 1.3-fold (0.11 log units) above it, and the stated range covers the measured number.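

In this assay, hydrogen gives this aromatic carbon a readable number, which sizes the loss of dimethylamino: an at least 32-fold lower number from compound 3 to compound 4 (1.50 log units; beyond the scatter). Fluoro can now also be set against hydrogen at the same carbon, para to a large group, and hydrogen in place of fluoro gives only a modest change, a 3.5-fold higher number from compound 1 to compound 4 (0.54 log units; beyond the scatter), so this position tolerates hydrogen far better than dimethylamino. On the carbonyl carbon, phenyl also stands well clear of quinolin-4-yl, with an at least 32-fold lower number from compound 2 to compound 4 (1.50 log units; beyond the scatter).

On these data alone, how far compound 2 and compound 3 actually lie from compound 4 stays open, as each of the two has only a limit: the limit of > 10000 nM in this assay, at which 2 of the 4 values shown sit. Also open, as far as these compounds go, is whether a chloro, methoxy or primary amine group at this aromatic carbon would stay near compound 1 and compound 4 or fall away like dimethylamino.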